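A few compounds are considered here, and "the series" means these few. Any claim that something is new, unique, unknown or untested is made for them only; others in the source may bear on it.

Working notes on the series. In a functional assay on M14 cells (Homo sapiens) for cytotoxicity, read by MTT assay, with a stated time of 72 h (on this read-out lower numbers stand for stronger inhibition and higher numbers for weaker inhibition), compound 1 `COc1cc(/C(=C\c2cn(C(C)=O)c3ccc(OCc4ccccc4)cc23)C(=O)O)cc(OC)c1OC` gives 57100 nM. Compound 2 `CC(=O)n1cc(/C=C(/C(=O)O)c2ccc(OCc3ccccc3)cc2)c2cc(OCc3ccccc3)ccc21` gives 58200 nM in this assay, and compound 3 `COc1ccc(Cn2cc(/C=C(/C(=O)O)c3ccccc3)c3cc(OCc4ccccc4)ccc32)cc1` gives 64500 nM. The three numbers sit within the usual scatter of one another, so compound 1 cannot be separated from compound 2 or compound 3 on this read-out; all three sit in the same band of weak inhibition.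

Compound 4 `COc1ccc(OC)c(/C(=C\c2cn(C(C)=O)c3ccc(OCc4ccccc4)cc23)C(=O)O)c1` has not yet been measured in this assay. It differs from compound 1 in one place: 2,5-dimethoxyphenyl in place of 3,4,5-trimethoxyphenyl on a double-bonded chain carbon bound to a carbonyl carbon and a double-bonded chain carbon. Going by the values given here, no pair of measured compounds shows a change of this kind, so the size of the step has no precedent here. The three measured compounds cover several different changes at the aromatic ring on the chain and at the core, yet all land in the same band, which gives no ground to expect a shift beyond the scatter in either direction for compound 4.

Compound 4 is therefore expected to give 60000 nM in this assay, with a range from 25000 nM to 150000 nM. The expected step from compound 1 to compound 4 is a 1.1-fold higher number from compound 1 to compound 4 (0.02 log units; within the scatter), no more than the scatter.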

Compound 4, half-maximal inhibitory concentration: 87100 nM
Beside the measured number, compound 4's estimate is 1.5-fold (0.16 log units) below it, within the range that was stated.
By their numbers in this assay, from the lowest: compounds 1, 2, 3 and 4 (each within the scatter of the next).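

Going by these compounds alone, on a double-bonded chain carbon bound to a carbonyl carbon and a double-bonded chain carbon, 2,5-dimethoxyphenyl in place of 3,4,5-trimethoxyphenyl gives the first single-place step: in this assay, there is a 1.5-fold higher number from compound 1 to compound 4 (0.18 log units; within the scatter). Within the data shown here, the first direct reading at this position therefore shows that this change, which leaves one methoxy group fewer on the ring, does not separate compound 4 from compound 1 on this read-out. Nothing available explains this outcome.

Open, going by these compounds, is whether any ring at this place can give a step beyond the scatter, since both rings compared here carry only methoxy groups. A phenyl ring bearing an amine or a carboxylic acid at this place, on the otherwise unchanged structure of compound 1, would test that.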